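The source may hold more compounds than are shown below. What is called first, only, known or untested is meant among the compounds shown, and "the series" means these compounds.

Measured compounds:
- compound 1 `CN1CCN(CCCN(c2nc3cc(F)c(F)cc3[nH]2)[C@@H]2CC[C@]3(c4cccc(C#N)c4)C[C@@H]3C2)CC1`: 21 nM
- compound 2 `CN1CCN(CCCN(c2nc3cc(F)c(F)cc3[nH]2)[C@@H]2CC[C@]3(c4cccc(CN5CCC[C@H]5CO)c4)C[C@@H]3C2)CC1`: 3000 nM

Both numbers come from an assay on CHO cells for antagonist activity at melanin-concentrating hormone receptor 1 (Homo sapiens), read by luminescence and calcium flux, with a stated time of 10 min; on this read-out lower numbers stand for stronger inhibition and higher numbers for weaker inhibition. Going by the values given here, compound 2 stands at the highest number of the two, with compound 1 as its only neighbour, far below it. Among the compounds with values here, the one measured step in the set is a 140-fold higher number from compound 1 to compound 2 (2.15 log units; beyond the scatter), and it is large and well beyond the scatter.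

Compound 3 `CN1CCN(CCCN(c2nc3cc(F)c(F)cc3[nH]2)[C@@H]2CC[C@]3(c4cccc(CO)c4)C[C@@H]3C2)CC1` is not yet measured. Relative to compound 2 the change is hydroxy in place of 2-(hydroxymethyl)pyrrolidin-1-yl on a saturated chain carbon bound to an aromatic carbon; cut one bond further out, the same change reads (2-(hydroxymethyl)pyrrolidin-1-yl)methyl to hydroxymethyl. Within the data shown here, only the step from compound 1 to compound 2 bears on it: that step attached the large pyrrolidine-bearing group at this position and cost a great deal, and compound 3 removes that group again while keeping a small substituent on the ring, as compound 1 does. A large step back toward the number of compound 1 is therefore expected, though not necessarily a full return, since hydroxymethyl is not cyano. The step to compound 3 is estimated as a 38-fold lower number from compound 2 to compound 3 (1.57 log units; beyond the scatter), and compound 3 is expected to give 80 nM, within 15 nM to 500 nM.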

Compound 3, half-maximal inhibitory concentration: 71 nM
Beside the measured number, compound 3's estimate is 1.1-fold (0.05 log units) above it, within the range that was stated.
By their numbers in this assay, from the lowest: compound 1; then compound 3; then compound 2.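

In this assay, hydroxy in place of 2-(hydroxymethyl)pyrrolidin-1-yl on a saturated chain carbon bound to an aromatic carbon gives a 42-fold lower number from compound 2 to compound 3 (1.63 log units; beyond the scatter) and so recovers most of the loss seen with the larger group. The recovery is incomplete, since hydroxymethyl in place of cyano on an aromatic carbon leaves a 3.4-fold higher number from compound 1 to compound 3 (0.53 log units; beyond the scatter), a modest step that is still beyond the scatter, so this position separates these two smaller groups as well as separating either of them from (2-(hydroxymethyl)pyrrolidin-1-yl)methyl. Nothing available on the series accounts for either difference.

The compounds shown leave open whether the large cost belongs to the pyrrolidine ring, to its hydroxymethyl branch or simply to the number of atoms added, and a plain pyrrolidine, a dimethylamino group or a methoxy group on the same saturated chain carbon would help to separate these readings. They also leave open how far a carboxylic acid or a primary amide in place of cyano on the aromatic carbon would follow compound 1 or compound 3.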